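Three Dimethoxyphenyl Cousins and a Trimethoxyphenyl Newcomer

A few compounds are considered here, and "the series" means these few. Any claim that something is new, unique, unknown or untested is made for them only; others in the source may bear on it.

Measured so far:
compound 1, `COc1cc(CNC(=O)/C=C/c2cccc(OC)c2OC)ccc1OCc1nc(C)c(C)nc1C`: 7150 nM
compound 2, `COc1ccc(/C=C/C(=O)NCc2ccc(OCc3nc(C)c(C)nc3C)c(OC)c2)cc1OC`: 4470 nM
compound 3, `COc1cc(/C=C/C(=O)NCc2ccc(OCc3nc(C)c(C)nc3C)c(OC)c2)cc(OC)c1`: 8660 nM

All three share one core and differ only in the methoxy-bearing phenyl that sits on a double-bonded chain carbon. In a functional assay on SH-SY5Y cells (Homo sapiens) for cytotoxicity, read by MTT assay, with stated times of 24 h and 4 h (a higher number here means that more compound is needed for the effect, a lower number that less compound is needed), compound 3 gives 8660 nM. Its two companions lie close: the changes were a 1.2-fold higher number from compound 1 to compound 3 (0.08 log units; within the scatter) and a 1.9-fold higher number from compound 2 to compound 3 (0.29 log units; within the scatter), so the three numbers sit together and none can be set apart from the others.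

Compound 4, `COc1cc(OC)c(OC)cc1/C=C/C(=O)NCc1ccc(OCc2nc(C)c(C)nc2C)c(OC)c1`, continues the pattern of swapping that phenyl: 2,4,5-trimethoxyphenyl in place of 3,5-dimethoxyphenyl on a double-bonded chain carbon bound to a double-bonded chain carbon. Every earlier step bears on it. Each of them also exchanged one methoxy-bearing phenyl for another: a 1.6-fold lower number from compound 1 to compound 2 (0.20 log units; within the scatter) alongside the two steps already named. Rearranging two methoxy groups left this assay unmoved; adding a third has no precedent among these compounds, so the expectation is no step beyond the scatter, with a wider range to allow for the new group. Compound 4 is therefore expected to give 6500 nM, somewhere between 2500 nM and 18000 nM. This amounts to an expected step of a 1.3-fold lower number from compound 3 to compound 4 (0.12 log units; within the scatter).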

Compound 4, half-maximal effective concentration: 3620 nM
Compound 4: the middle estimate sits 1.8-fold (0.25 log units) above what was measured, and the stated range covers the measured number.
By their numbers in this assay, from the lowest: compounds 4, 2, 1 and 3 (each within the scatter of the next, the first and the last beyond it).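

In this assay the phenyl on a double-bonded chain carbon now gives its first step beyond the scatter, and a modest one (a 2.4-fold lower number from compound 3 to compound 4 (0.38 log units; beyond the scatter)), with 2,4,5-trimethoxyphenyl in place of 3,5-dimethoxyphenyl. A third methoxy does not set compound 4 apart from the whole set: methoxy in place of hydrogen on an aromatic carbon stays within the scatter (a 1.2-fold lower number from compound 2 to compound 4 (0.09 log units; within the scatter)), as does the exchange for 2,3-dimethoxyphenyl (a 2.0-fold lower number from compound 1 to compound 4 (0.30 log units; within the scatter)), so the clear separation holds only for the two ends of a closely spaced series. No accompanying observation offers an explanation for this separation.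

From the compounds shown here alone, it remains open whether a hydroxy group or a fluorine atom on this phenyl would give a number that stands clearly apart from all four compounds. Every compound shown also keeps the same shared core, so the effect of an amine or a longer chain elsewhere in the structure remains unknown.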